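This account rests on a few compounds, and the source may have more. Where it says the series, first, only, none or still open, it means among the compounds named here.

Compound 1 `NCc1csc(NC(=O)c2cc3ccccc3[nH]2)n1`: > 100 ug/mL
Compound 2 `CC(C)(C)c1cc(C(=O)Nc2ccncc2)n(Cc2ccccc2)n1`: > 100 ug/mL
Compound 3 `NCc1csc(NC(=O)c2ccccc2)n1`: > 100 ug/mL

In a physicochemical assay for solubility, read by nephelometry, measured as kinetic solubility, at pH 2.0 (a higher number here means a more soluble compound, a lower number a less soluble compound), compound 1 gives > 100 ug/mL, which is a limit of the assay rather than a number. Compound 2 gives > 100 ug/mL, again a limit. Compound 3 gives > 100 ug/mL, also a limit. Compound 2 therefore stands exactly where every value shown stands, namely at the limit of > 100 ug/mL in this assay, at which 3 of the 3 values shown sit, so its true solubility is not resolved.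

The unmeasured compound 4 `CC(C)(C)c1cc(C(=O)Nc2nc(CO)cs2)n(Cc2ccccc2)n1` differs from compound 2 by 4-(hydroxymethyl)-1,3-thiazol-2-yl in place of pyridin-4-yl on an amide-type nitrogen. Going by the values given here, no measured pair isolates this change, so its size is unknown from these data; nothing among the three measured values departs from the limit. Compound 4 is expected to stay at or near that limit, with the step of a number no higher from compound 2 to compound 4 (the limit leaves the size open) estimated as no more than the usual scatter. Compound 4 is estimated at 100 ug/mL, between 50 ug/mL and 200 ug/mL.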

Compound 4, solubility: 12.5 ug/mL
The estimate for compound 4 lay 8.0-fold (0.90 log units) above the measured number; measured number below the stated range.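

In this assay, 4-(hydroxymethyl)-1,3-thiazol-2-yl in place of pyridin-4-yl on an amide-type nitrogen gives an at least 8.0-fold lower number from compound 2 to compound 4 (0.90 log units; beyond the scatter). Going by these compounds alone, compound 4 is the first compound here with a measured number rather than a limit, so the group on this nitrogen can shift the read-out. The value of compound 2 is a limit, which leaves the full size of the step unresolved: the limit of > 100 ug/mL in this assay, at which 3 of the 4 values shown sit.

From the compounds shown here alone, whether the ring or its hydroxymethyl carries the step remains open, since both change together. Going by these compounds, how a carboxylic acid in place of the hydroxymethyl would read also remains unknown.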